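The compounds below may be only part of what the source reports. "The series", "measured", "known", "first", "only" and "open" are said of these compounds alone.

Compound 1 `C=C(C)CCOC(=O)C[C@@H]1C(C(=O)OC)=CO[C@@H](O[C@@H]2O[C@H](COC(C)=O)[C@@H](OC(C)=O)[C@H](OC(C)=O)[C@H]2OC(C)=O)/C1=C/C` was tested in a functional assay on SK-BR-3 cells (Homo sapiens) for antiproliferative activity, read by MTT assay, with a stated time of 72 h; on this read-out higher numbers stand for weaker inhibition and lower numbers for stronger inhibition. For compound 1 the result is a limit of the assay rather than a number, > 15000 nM. The two other values shown are limits as well, so compound 1 cannot be ranked against them. Compound 2 `C/C=C1/[C@H](O[C@@H]2O[C@H](CO)[C@@H](O)[C@H](O)[C@H]2O)OC=C(C(=O)OC)[C@H]1CC(=O)OCCCc1ccc(OC)c(OC)c1` likewise gives only a limit in this assay, > 20000 nM. Compound 3 `C/C=C1/[C@H](O[C@@H]2O[C@H](CO)[C@@H](O)[C@H](O)[C@H]2O)OC=C(C(=O)OC)[C@H]1CC(=O)OC` also gives only a limit in this assay, > 15000 nM. For the measured compounds named here, the one change between measured compounds, hydrogen in place of 2-(3,4-dimethoxyphenyl)ethyl on a saturated chain carbon bound to an oxygen next to a carbonyl group, yields a step that the two limits leave unreadable from compound 2 to compound 3. All the measurements show is the limit of > 15000 nM in this assay, at which 2 of the 3 values shown sit, and (the limit of > 20000 nM in this assay, at which 1 of the 3 values shown sits).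

Compound 4 `C/C=C1/[C@H](O[C@@H]2O[C@H](COC(C)=O)[C@@H](OC(C)=O)[C@H](OC(C)=O)[C@H]2OC(C)=O)OC=C(C(=O)OC)[C@H]1CC(=O)OCCC` differs from compound 1 by methyl in place of 1-methylethenyl on a saturated chain carbon, two bonds along the chain from an oxygen next to a carbonyl group. Going by the values given here, no measured step bears on this change, since every value shown is a limit, so neither a direction nor a size can be read from the data. Compound 4 is therefore expected to give 20000 nM, with a likely range from 8000 nM to 60000 nM, most probably again as a limit. This estimate amounts to a step that the limit leaves unreadable from compound 1 to compound 4, that is, no change beyond the scatter is expected.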

Compound 4, half-maximal inhibitory concentration: 6600 nM
Beside the measured number, compound 4's estimate is 3.0-fold (0.48 log units) above it; the measured number lies below the stated range.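

In this assay, putting methyl in place of 1-methylethenyl, on a saturated chain carbon, two bonds along the chain from an oxygen next to a carbonyl group, gives an at least 2.2-fold lower number from compound 1 to compound 4 (0.35 log units; beyond the scatter). For the compounds shown here, this is the first sign that the group at this place can change the read-out, and the step is a minimum, since its starting point, compound 1, is a limit of the assay and not a number. No other step can be read, because the remaining values are limits as well: the limit of > 15000 nM in this assay, at which 2 of the 4 values shown sit.

The change removes a double bond and shortens the group in one move, so the compounds shown do not tell which of the two matters, or whether both do. From the compounds shown here alone, it also stays open whether the number would fall further or rise again with ethyl, a longer chain such as butyl, or an amine or a carboxylic acid in place of the methyl of compound 4.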